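Swapping one piperidine substituent for another

A few compounds are considered here, and "the series" means these few. Any claim that something is new, unique, unknown or untested is made for them only; others in the source may bear on it.

Measured compounds:
Compound 1, `Cc1cc(C)c(S(=O)(=O)N2CCC(c3ccccc3)CC2)c(C)c1`, reaches only the limit > 5000 nM in a functional assay on DLD-1 cells (Homo sapiens) for antiproliferative activity, read by CellTiter-Glo, with a stated time of 72 h; on this read-out higher numbers stand for weaker inhibition and lower numbers for stronger inhibition.
Compound 2, `Cc1ccc(C2CCN(S(=O)(=O)c3c(C)cc(C)cc3C)CC2)cc1`, gives 2200 nM in this assay.
Compound 3, `Cc1cc(C)c(S(=O)(=O)N2CCC(N3CCC(C(C)C)CC3)CC2)c(C)c1`, gives 0.3 nM in this assay.

Among the two real numbers, compound 3 stands lowest, and its nearest neighbour is compound 2, separated by a 7300-fold lower number from compound 2 to compound 3 (3.87 log units; beyond the scatter). Compound 1 sits at a limit, (the limit of > 5000 nM in this assay, at which 1 of the 3 values shown sits), so its gap to compound 3 can only be stated as an at least 16000-fold lower number from compound 1 to compound 3 (4.22 log units; beyond the scatter). The smaller step of an at least 2.2-fold lower number from compound 1 to compound 2 (0.35 log units; beyond the scatter) concerns the aryl series alone.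

Compound 4, `Cc1cc(C)c(S(=O)(=O)N2CCC(N3CC(C)CC(C)C3)CC2)c(C)c1`, keeps the shared core and the piperidine attached to it but changes its substituents: 3,5-dimethylpiperidin-1-yl in place of 4-isopropylpiperidin-1-yl on a saturated ring carbon. For the measured compounds named here, no measured step alters the substituent pattern on this piperidine; the two large steps into compound 3 both replaced an aromatic ring with the 4-isopropylpiperidin-1-yl group, so they show that the piperidine itself carries most of the gain, not which alkyl groups sit on it. A modest shift in this assay is therefore expected, most likely a small rise in the number, possibly within the scatter. Compound 4 is estimated at 1 nM, with a range from 0.2 nM to 6 nM, meaning an expected step of a 3.3-fold higher number from compound 3 to compound 4 (0.52 log units; beyond the scatter).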

Compound 4, half-maximal inhibitory concentration: 17 nM
Estimate against measurement, compound 4: 17-fold (1.23 log units) below; measured number above the stated range.
By their numbers in this assay, from the lowest: compound 3; then compound 4; then compound 2. At a limit, above all of these: compound 1.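

In (this assay), the alkyl groups on the piperidine matter in their own right, not only the ring that carries them. With 3,5-dimethylpiperidin-1-yl in place of 4-isopropylpiperidin-1-yl on the same saturated ring carbon, the result is a large loss (a 57-fold higher number from compound 3 to compound 4 (1.75 log units; beyond the scatter)), even though both groups are six-membered non-aromatic rings with 1 nitrogen. The advantage over the aromatic groups nevertheless holds for this second piperidine (a 130-fold lower number from compound 2 to compound 4 (2.11 log units; beyond the scatter); an at least 290-fold lower number from compound 1 to compound 4 (2.46 log units; beyond the scatter)), so compound 3 is not the only piperidine that outperforms them, although the second of these steps is only a bound, since the value of compound 1 is a limit and not a number: the limit of > 5000 nM in this assay, at which 1 of the 4 values shown sits.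

Compound 3 and compound 4 differ in both the number and the placement of their alkyl groups, so the compounds shown cannot separate these two changes. As far as these compounds go, it also remains open how a piperidine bearing a single methyl or a tert-butyl group, or a morpholine at the same carbon, would behave in (this assay).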